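Shortening a Long Chain on Two Related Cores

This account rests on a few compounds, and the source may have more. Where it says the series, first, only, none or still open, it means among the compounds named here.

Compound 1, `CCCCCCCCCCCN1NN=C(NC(=O)Nc2c(C(C)C)cccc2C(C)C)N1`, and compound 2, `CCCCCCCCCCCCCN1NN=C(NC(=O)Nc2c(C(C)C)cccc2C(C)C)N1`, share a core and differ only along a saturated chain. In an assay on microsomes from intestine for inhibition of acyl-CoA:cholesterol acyltransferase (Oryctolagus cuniculus) (on this read-out higher numbers stand for weaker inhibition and lower numbers for stronger inhibition), compound 1 gives 9 nM, and compound 2 gives 9 nM. The change between them is hydrogen in place of ethyl on a saturated chain carbon, ten or more bonds along the chain from an amine nitrogen in a ring, and the step it made, no change at the digits printed from compound 2 to compound 1 (within the scatter), shows that on this pair the chain change left the read-out where it was.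

Compound 3, `CCCCCCCCCCCCCc1nnc(NC(=O)Nc2c(C(C)C)cccc2C(C)C)s1`, carries the chain of compound 2 on a different core; how its core differs from that of compound 2 is not broken down here. In this assay compound 3 gives 36 nM, a number beyond the scatter from those of compound 1 and compound 2.

Compound 4, `CCCCCCCCCCCc1nnc(NC(=O)Nc2c(C(C)C)cccc2C(C)C)s1`, is not yet measured. It differs from compound 3 by hydrogen in place of ethyl on a saturated chain carbon, ten or more bonds along the chain from an aromatic carbon. Among the compounds with values here, this is the same kind of change as the one between compound 2 and compound 1, but not the same: in the measured pair the chain is counted from an amine nitrogen in a ring, whereas here it is counted from an aromatic carbon. Within the data shown here, only the one measured pair shows what such a change does, and it does so on another core.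

The expected step is no change at the digits printed from compound 3 to compound 4 (within the scatter), resting on the measured step of no change at the digits printed from compound 2 to compound 1 (within the scatter) for the same kind of change. Compound 4 is therefore estimated at 36 nM in this assay, expected to fall between 15 nM and 85 nM.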

Compound 4, half-maximal inhibitory concentration: 390 nM
Compound 4: middle estimate off by 11-fold (1.03 log units), on the low side; measured number above the stated range.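

In this assay, putting hydrogen in place of ethyl on a saturated chain carbon, ten or more bonds along the chain from an aromatic carbon, gave an 11-fold higher number from compound 3 to compound 4 (1.03 log units; beyond the scatter). Set beside the earlier step on the core of compound 1, this shows that the same chain change does not carry the same result from one core to the other in this series: the same change on two cores in this assay, no change at the digits printed (within the scatter) from compound 2 to compound 1 and an 11-fold higher number (1.03 log units; beyond the scatter) from compound 3 to compound 4, 11-fold (1.03 log units) apart, beyond the scatter of two such steps

Within the data shown here, a step measured on one of these cores is therefore a poor guide to the same step on the other, but each core supplies only a single pair, so the result shows neither why the two cores part ways nor whether the gap would hold at other chain lengths.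

A shorter chain on the core of compound 1 would show whether that core also gives a higher number once the chain is cut further, and a longer chain on the core of compound 3 would show whether the number there keeps falling as the chain grows. From the compounds shown here alone, whether a chain carrying an amine or a carboxylic acid would behave like these plain saturated chains also remains open.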